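Three Cytotoxicity Limits and an Expected Fourth

The source may hold more compounds than are shown below. What is called first, only, known or untested is meant among the compounds shown, and "the series" means these compounds.

Compound 1 `CCOC(=O)[C@@H]1C[C@@]23CN(C)C[C@@H](CCC4=C2[C@@H]1CC4=O)C31CC[C@](CC)(OC)OC1`: > 40000 nM
Compound 2 `CC[C@]1(OC)CCC2(CO1)[C@@H]1CCC3=C4[C@H](CC3=O)[C@H](C(=O)OC)C[C@@]42CN(C)C1`: > 40000 nM
Compound 3 `CCC1=CCC2(CO1)[C@@H]1CCC3=C4[C@H](CC3=O)[C@H](C(=O)OC)C[C@@]42CN(C)C1`: > 40000 nM

The three measured compounds were tested in a functional assay on HL-60 cells (Homo sapiens) for cytotoxicity, read by MTT assay, with a stated time of 48 h; on this read-out lower numbers stand for stronger inhibition and higher numbers for weaker inhibition. In this assay compound 1 reaches only a limit of the assay, not a number, > 40000 nM. Compound 2 likewise stops at a limit, > 40000 nM. Compound 3 too is reported as a limit, > 40000 nM. All three values therefore sit at the same point, (the limit of > 40000 nM in this assay, at which 3 of the 3 values shown sit), and no ordering among them can be read.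

Compound 1 and compound 2 differ in a single place: methyl in place of hydrogen on a saturated chain carbon bound to an oxygen next to a carbonyl group. The step that the two limits leave unreadable from compound 2 to compound 1 cannot be sized, since both ends of it are limits. How the core of compound 3 differs from the core of compound 2 is not broken down here.

Compound 4 `COC(=O)[C@@H]1C[C@@]23CN(C)C[C@@H](CCC4=C2[C@@H]1CC4=O)C31CC=C(C(C)C)OC1` has not yet been measured. It differs from compound 3 in one place: methyl in place of hydrogen on a saturated chain carbon bound to a double-bonded ring carbon and a saturated chain carbon. This is the same kind of change as that from compound 2 to compound 1, but its place is a saturated chain carbon bound to a double-bonded ring carbon and a saturated chain carbon, whereas the earlier one sat on a saturated chain carbon bound to an oxygen next to a carbonyl group.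

Since every related compound sits at the limit, the step from compound 3 to compound 4 is expected to be small, a step that the limit leaves unreadable from compound 3 to compound 4, and compound 4 is expected to remain at or beyond the limit, estimated at 60000 nM, between 20000 nM and 200000 nM.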

Compound 4, half-maximal inhibitory concentration: > 40000 nM
Compound 4 ended at the assay's limit (the forecaster's own chance of this, stated with the estimate: 85%); the middle value does not contradict the limit.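

In this assay, among these compounds, compound 3 and compound 4 both stop at a limit of the assay, so the change from ethyl to isopropyl yields no step that can be read, and none of the four compounds can be ranked: the limit of > 40000 nM in this assay, at which 4 of the 4 values shown sit. The compounds shown leave open whether any change to the shared core or its groups would give a number rather than a limit.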